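The compounds below may be only part of what the source reports. "The series", "measured", "known", "first", "only" and "open" are said of these compounds alone.

In an ADME assay on microsomes from liver (Rattus norvegicus) for metabolic stability, read by LC-MS, using NADPH, with a stated time of 30 min, tested at 1 uM (a lower number here means slower removal, a higher number faster removal of the compound), compound 2 `NC1=N[C@@]2(CO1)c1cc(NC(=O)c3ccc(Cl)cn3)ccc1Oc1cnc(Cl)cc12` gives only a limit, < 14 mL.min-1.g-1. It thus sits at the limit of < 14 mL.min-1.g-1 in this assay, at which 1 of the 2 values shown sits. Compound 3 `CC#Cc1cncc(-c2ccc3c(c2)[C@@]2(COC(N)=N2)c2cc(Cl)ncc2O3)c1` has 5-(prop-1-yn-1-yl)pyridin-3-yl in place of ((5-chloropyridin-2-yl)carbonyl)amino on an aromatic carbon. Compound 1 `CC#Cc1cncc(-c2ccc3c(c2)[C@@]2(COC(N)=N2)c2cc(-c4ccnc(F)c4)ncc2O3)c1` also carries the 5-(prop-1-yn-1-yl)pyridin-3-yl group and gives 20 mL.min-1.g-1 in this assay, and that value anchors the expectation here. A modest move towards faster removal is expected, with an estimated step of an at least 1.4-fold higher number from compound 2 to compound 3 (0.15 log units; that floor lies within the scatter). The estimate for compound 3 is 20 mL.min-1.g-1, with an expected range from 12 mL.min-1.g-1 to 38 mL.min-1.g-1.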

Compound 3, intrinsic clearance in microsomes: 21 mL.min-1.g-1
For compound 3 the middle estimate is 1.1-fold (0.02 log units) below the measured one; low and high end bracket the measured number.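

In this assay, the exchange of ((5-chloropyridin-2-yl)carbonyl)amino for 5-(prop-1-yn-1-yl)pyridin-3-yl gives an at least 1.5-fold higher number from compound 2 to compound 3 (0.17 log units; that floor lies within the scatter), so only a floor is known for this step, and that floor does not clear the scatter. Compound 2 is known only by a limit: the limit of < 14 mL.min-1.g-1 in this assay, at which 1 of the 3 values shown sits. With 5-(prop-1-yn-1-yl)pyridin-3-yl in place, chloro in place of 2-fluoropyridin-4-yl gives a 1.1-fold higher number from compound 1 to compound 3 (0.02 log units; within the scatter), a first sign that this second exchange leaves the read-out within the scatter.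

On these data alone, whether an amine or a methoxy group in place of the chloro would do the same remains open.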